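From (tert-butyl)carbonyl Amide to Free Amine

The source may report more compounds than this note shows. Statements on the series, on what has been measured and on what is new or still open speak of the compounds shown alone.

Of the compounds shown here, three have been measured in a functional assay on K562 cells (Homo sapiens) for inhibition, read by MTT assay, with a stated time of 48 h; a higher number here means a weaker inhibitor, a lower number a stronger inhibitor. Compound 1 `CC(C)(C)C(=O)Nc1ccc(-c2cccc(C(=O)N[C@H]3CN[C@@H](C(=O)Nc4ccc(Cl)c(C(F)(F)F)c4)C3)c2)cn1` gives 28000 nM. Compound 3 `CS(=O)(=O)Nc1ccc(-c2ccc(C(=O)N[C@H]3CN[C@@H](C(=O)Nc4ccc(Cl)c(C(F)(F)F)c4)C3)cc2)cn1` gives 45000 nM, and the two numbers lie within the scatter of each other, so no order between them can be read. Compound 2 `C[C@H](NC(=O)c1ccc(-c2ccc(N)nc2)cc1)C(=O)Nc1ccc(Cl)c(C(F)(F)F)c1`, built on a different core, gives 5950 nM, which puts it beyond the scatter from compound 1, on the stronger side. Among the three numbers, compound 1 thus stands second highest.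

Compound 4 `Nc1ccc(-c2cccc(C(=O)N[C@H]3CN[C@@H](C(=O)Nc4ccc(Cl)c(C(F)(F)F)c4)C3)c2)cn1` keeps the core of compound 1 and differs in one place: hydrogen in place of (tert-butyl)carbonyl on a nitrogen on an aromatic ring. The change leaves the group that carries the amide to the aromatic ring intact and only removes the acyl group on the nitrogen.

For the measured compounds named here, no measured pair shows this exact change, so its effect has to be estimated. Compound 2, which also carries a free amino group on its aromatic ring, gives 5950 nM, but it also differs from compound 1 in its core, so it can only loosely guide the estimate. Compound 4 is therefore expected to move from compound 1 by a 1.9-fold lower number from compound 1 to compound 4 (0.27 log units; within the scatter), a modest step toward a lower number that may still fall within the scatter. The estimate for compound 4 in this assay is 15000 nM, with a range from 5000 nM to 45000 nM.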

Compound 4, half-maximal inhibitory concentration: 20000 nM
Compound 4: middle estimate off by 1.3-fold (0.12 log units), on the low side; the range from low to high includes it.
By their numbers in this assay, from the lowest: compound 2; then compounds 4, 1 and 3 (each within the scatter of the next, the first and the last beyond it).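

In this assay the change from ((tert-butyl)carbonyl)amino to amino gives a 1.4-fold lower number from compound 1 to compound 4 (0.15 log units; within the scatter) and this step lies within the scatter, so compound 1 and compound 4 cannot be put in order. This is the first pair among the compounds shown that isolates this position, and it shows that all 6 heavy atoms of the (tert-butyl)carbonyl group can leave the nitrogen on the aromatic ring without a difference that this read-out can resolve on the core of compound 1. No further data on hand bear on this result.

The compounds shown leave open whether another group on this nitrogen, such as an acetyl group, a methyl group or a longer chain ending in a carboxylic acid, would give a number beyond the scatter from that of compound 1. They also leave open whether the same exchange of (tert-butyl)carbonyl for hydrogen would read alike if a nitrile replaced the trifluoromethyl group of the shared core.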